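Compound 3: methoxy in place of chloro

The source may hold more compounds than are shown below. What is called first, only, known or untested is meant among the compounds shown, and "the series" means these compounds.

Measured so far:
- compound 1 `COc1ccc(-c2cc(O)c3cccnc3n2)cc1` gives 17800 nM here
- compound 2 `Cc1cnc2nc(-c3ccc(Cl)cc3)cc(O)c2c1` gives 2820 nM here

Both values come from a functional assay on HCT-116 cells (Homo sapiens) (on this read-out lower numbers stand for stronger inhibition of growth and higher numbers for weaker inhibition of growth), and the gap between them lies beyond the scatter. Compound 2 holds the lower of the two numbers, with compound 1 as its nearest neighbour above.

The next compound is compound 3 `COc1ccc(-c2cc(O)c3cc(C)cnc3n2)cc1`, still to be measured. Relative to compound 2 it carries methoxy in place of chloro on an aromatic carbon, para to a large group methoxy in place of chloro on an aromatic carbon as the single change.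

For the measured compounds named here, no pair of measured compounds differing in one place is available, so this swap has no direct precedent. Going by the values given here, the only guide is compound 1, which also carries a methoxy and gives 17800 nM in this assay as its result. On that basis, a moderate move towards weaker inhibition of growth is expected, probably just beyond the scatter. The expected size is a 2.3-fold higher number from compound 2 to compound 3 (0.36 log units; beyond the scatter) in this estimate. Compound 3 is estimated at 6500 nM (2500 nM to 16000 nM).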

Compound 3, concentration for 50% growth inhibition: 4170 nM
The estimate for compound 3 lay 1.6-fold (0.19 log units) above the measured number, within the range that was stated.
By their numbers in this assay, from the lowest: compounds 2 and 3 (each within the scatter of the next); then compound 1.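

In this assay, methoxy in place of chloro on an aromatic carbon, para to a large group, gives a 1.5-fold higher number from compound 2 to compound 3 (0.17 log units; within the scatter), so this read-out does not separate the two groups at this position. For the compounds shown here, the other single change, methyl in place of hydrogen on an aromatic carbon of the shared core with the methoxy held constant, gives a 4.3-fold lower number from compound 1 to compound 3 (0.63 log units; beyond the scatter), which makes it the only one of the two steps that lies beyond the scatter and points to the core position, not the para group, as the more responsive site so far. No measurement available here accounts for the size of either step.

From the compounds shown here alone, whether the methyl step carries over when chloro replaces methoxy remains open, as does whether a larger group on the same core carbon, such as an ethyl chain or a primary amine, would extend it. Going by these compounds alone, it is also unknown whether the insensitivity para to the large group would hold for a very different group there, such as a carboxylic acid or a dimethylamino group, since methoxy and chloro are the only two groups compared at this position.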